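Flipping one ring stereocentre in a nicotinic binder

The source may hold more compounds than are shown below. What is called first, only, known or untested is meant among the compounds shown, and "the series" means these compounds.

Measured so far:
Compound 1 `Fc1cccc(-c2cn([C@@H]3CN4CCC3CC4)nn2)c1` gives 519 nM in an assay on HEK293 cells for displacement of a labelled ligand from Neuronal acetylcholine receptor; alpha4/beta2 (Homo sapiens), read by scintillation counting, with a stated time of 120 min; a lower number here means a stronger inhibitor, a higher number a weaker inhibitor.
Compound 2 `Fc1ccc(-c2cn([C@@H]3CN4CCC3CC4)nn2)cc1` gives 515 nM in this assay.
Compound 3 `Oc1ccc(-c2cn([C@@H]3CN4CCC3CC4)nn2)cc1` gives 461 nM in this assay.

Compound 2 stands second highest of the three numbers, but its neighbours are close on both sides: compound 1 is nearest and compound 3 furthest, and both gaps lie within the scatter, so none of the three can be ordered against another. For the measured compounds named here, the one single-point step available is a 1.1-fold lower number from compound 2 to compound 3 (0.05 log units; within the scatter), which concerns the aromatic substituent and not the stereochemistry.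

Compound 4 `Fc1ccc(-c2cn([C@H]3CN4CCC3CC4)nn2)cc1` differs from compound 2 only in this way: the two compounds have the same atoms and bonds; at least one stereo element is drawn with a configuration in one of them and without one in the other: 1 of 3 stereo elements differ; a stereocentre at a saturated ring carbon is drawn S in compound 2 and R in compound 4. Going by the values given here, no measured pair involves a change at that ring carbon, so the measured step says nothing directly about the size or direction of this change. Among the compounds with values here, the three numbers show only that the shared core tolerates varied aromatic substituents at a similar level. With no guide to the effect of inverting the stereocentre, the expected outcome is uncertain in both directions, and the range must be wide.

The estimate for compound 4 is 1500 nM, within 250 nM to 9000 nM, which means an expected step of a 2.9-fold higher number from compound 2 to compound 4 (0.46 log units; beyond the scatter).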

Compound 4, inhibition constant: 10400 nM
For compound 4 the middle estimate is 6.9-fold (0.84 log units) below the measured one; the measured number lies above the stated range.
By their numbers in this assay, from the lowest: compounds 3, 2 and 1 (each within the scatter of the next); then compound 4.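

In this assay, changing only the saturated ring carbon from S to R, with every atom and bond kept, gives a 20-fold higher number from compound 2 to compound 4 (1.31 log units; beyond the scatter). For the compounds shown here, this is the first step that lies beyond the scatter, whereas the swap of fluoro for hydroxy on the aromatic ring gave only a 1.1-fold lower number from compound 2 to compound 3 (0.05 log units; within the scatter), so this stereocentre matters far more to the number than that aromatic change does. The record offers no measured property to explain the step, and the one point it holds on this pair concerns how the two structures are drawn: the fact that one of compounds 2 and 4 is drawn with a defined configuration and the other without, at the place where they differ

The compounds shown leave open whether the R configuration would cost as much with the hydroxy group of compound 3, or with the fluoro group placed as in compound 1, since only one pair tests this change. They also leave open whether a different group on the aromatic ring, such as an amine or a carboxylic acid, would keep the S and R forms as far apart as compound 2 and compound 4.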